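This account rests on a few compounds, and the source may have more. Where it says the series, first, only, none or still open, it means among the compounds named here.

Measured in a functional assay on cells for inhibition of Polyunsaturated fatty acid 5-lipoxygenase (Homo sapiens); on this read-out lower numbers stand for stronger inhibition and higher numbers for weaker inhibition:
- compound 1 `O=C1NCCN(c2cccc(OCc3ccccc3)c2)N1`: 200 nM
- compound 2 `CC1CN(c2cccc(F)n2)NC(=O)N1`: 6000 nM
- compound 3 `O=C1NCCN(c2cccc(Br)n2)N1`: 4600 nM

Compound 2 gives the highest of the three numbers in this assay. Compound 3 stands close to it, and the gap between the two is within the usual scatter, so no order between compound 2 and compound 3 can be read from these values. Compound 1 stands far lower, and that gap is well beyond the scatter.

The next compound, compound 4 `COc1cccc(N2CC(C)NC(=O)N2)n1`, has not yet been measured. It differs from compound 2 in one place: methoxy in place of fluoro on an aromatic carbon. For the measured compounds named here, no measured pair shows this same exchange, so the size of the step has to be guessed. Going by the values given here, the only compound in the set with an oxygen-linked substituent is compound 1, which gives a much lower number, though its core and ring differ in other ways as well. On this basis a modest move toward lower numbers, perhaps not beyond the scatter, is expected from compound 2 to compound 4, a 2.0-fold lower number from compound 2 to compound 4 (0.30 log units; within the scatter). For compound 4 the estimated value in this assay is 3000 nM, with an expected range from 1000 nM to 10000 nM.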

Compound 4, half-maximal inhibitory concentration: 7100 nM
Compound 4: middle estimate off by 2.4-fold (0.37 log units), on the low side; low and high end bracket the measured number.
By their numbers in this assay, from the lowest: compound 1; then compounds 3, 2 and 4 (each within the scatter of the next).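

In this assay, methoxy in place of fluoro on an aromatic carbon next to the ring nitrogen gives a 1.2-fold higher number from compound 2 to compound 4 (0.07 log units; within the scatter). For the compounds shown here, this is the first exchange that can be read at a single position, and it shows that swapping the lone fluorine for a group with one more heavy atom and a hydrogen-bond acceptor does not separate the two compounds beyond the scatter. No measurement shown here speaks to why this exchange gives so small a step.

Going by these compounds, whether an amine or a longer chain such as butoxy at this position would give a step beyond the scatter remains open. Also open, on these data alone, is what the methyl on the core of compound 2 contributes to the read-out.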